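From 2-hydroxyphenyl to 4-hydroxyphenyl: an open question

A few compounds are considered here, and "the series" means these few. Any claim that something is new, unique, unknown or untested is made for them only; others in the source may bear on it.

Measured in a functional assay on U-251 cells (Homo sapiens) for inhibition, read by sulforhodamine B assay, with a stated time of 48 h; a higher number here means a weaker inhibitor of growth, a lower number a stronger inhibitor of growth

- compound 1 (`O=C(Cc1csc2nc(-c3ccc(Br)cc3)cn12)N/N=C/c1ccccc1`) gives 12900 nM
- compound 2 (`O=C(Cc1csc2nc(-c3ccc(Br)cc3)cn12)N/N=C/c1ccccc1O`) gives 3630 nM

Compound 2 holds the lower of the two numbers. Going by the values given here, the only measured step (a 3.6-fold lower number from compound 1 to compound 2 (0.55 log units; beyond the scatter)) is modest but beyond the scatter, and it comes with hydroxy in place of hydrogen on an aromatic carbon.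

Compound 3 (`O=C(Cc1csc2nc(-c3ccc(Br)cc3)cn12)N/N=C/c1ccc(O)cc1`) has not yet been measured. It differs from compound 2 by 4-hydroxyphenyl in place of 2-hydroxyphenyl on a carbon with a double bond to nitrogen. Its atoms are the same, joined differently. Among the compounds with values here, no measured step shows a hydroxy group changing place, so the evidence is indirect. Within the data shown here, compound 3 keeps a hydroxy group, and the one step available (a 3.6-fold lower number from compound 1 to compound 2 (0.55 log units; beyond the scatter)) sets the only measured scale. A shift larger than that step is therefore not expected, and the direction is uncertain, with a slight lean towards a weaker inhibitor of growth. The estimated change is small and not clearly beyond the scatter (a 1.4-fold higher number from compound 2 to compound 3 (0.14 log units; within the scatter)). For compound 3 the expected value is 5000 nM (estimated range 2000 nM to 12000 nM).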

Compound 3, concentration for 50% growth inhibition: 21400 nM
Compound 3: the middle estimate sits 4.3-fold (0.63 log units) below what was measured, and the stated range ends below it.
By their numbers in this assay, from the lowest: compound 2; then compounds 1 and 3 (each within the scatter of the next).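

In this assay the place of the hydroxy group on the ring decides the outcome: with the same atoms joined differently, 4-hydroxyphenyl in place of 2-hydroxyphenyl gives a 5.9-fold higher number from compound 2 to compound 3 (0.77 log units; beyond the scatter) and so removes the advantage that compound 2 had held. Set against the compound without a hydroxy group, the new compound shows a 1.7-fold higher number from compound 1 to compound 3 (0.22 log units; within the scatter) and is not separated from it beyond the scatter, so the earlier gain belongs to the 2-hydroxyphenyl compound and not to a hydroxy group on this ring as such. Nothing available explains why the two placements differ.

The compounds shown leave open whether a methoxy group or an amine in the place of the hydroxy group on the 2-hydroxyphenyl ring would keep the lower number of compound 2 or lose it as compound 3 does. They also leave open whether the same difference between the two placements would return if the bromine on the shared core were replaced by chlorine.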